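The source may report more compounds than this note shows. Statements on the series, on what has been measured and on what is new or still open speak of the compounds shown alone.

Compounds measured in an ADME assay on Vero cells (Chlorocebus sabaeus) for cytotoxicity, read by MTT assay, with a stated time of 48 h; a higher number here means that more compound is tolerated, a lower number that less compound is tolerated:

Compound 1 `CN(C)c1ccc(C(C)(C)NC(=O)c2ccc([N+](=O)[O-])o2)cc1`: 79000 nM
Compound 2 `CC(C)(C)c1ccc(C(C)(C)NC(=O)c2ccc([N+](=O)[O-])o2)cc1`: > 150000 nM, a limit
Compound 3 `CC(C)(NC(=O)c1ccc([N+](=O)[O-])o1)c1ccc(C(F)(F)F)cc1`: > 150000 nM, a limit

Compound 3 has no number of its own. Its > 150000 nM is a limit of the assay. Compound 2 also has only a limit, > 150000 nM. The small set therefore rests largely on (the limit of > 150000 nM in this assay, at which 2 of the 3 values shown sit).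

Compound 4 `CC(C)(NC(=O)c1ccc([N+](=O)[O-])o1)c1ccc(COc2ccc(Cl)cc2)cc1` differs from compound 3 in one place, with (4-chlorophenoxy)methyl in place of trifluoromethyl on an aromatic carbon. Among the compounds with values here, no measured step involves this group, so the three steps at the same place bear on it only indirectly. They are an at least 1.8-fold higher number from compound 1 to compound 2 (0.27 log units; that floor lies within the scatter), an at least 1.8-fold higher number from compound 1 to compound 3 (0.27 log units; that floor lies within the scatter) and a step that the two limits leave unreadable from compound 2 to compound 3. None of them is shown to lie beyond the scatter. Only compound 1, at 79000 nM, has a number inside the range of this assay, which shows that a group at this place can leave a measurable value. A modest move to a lower number is therefore expected, though another limit remains quite possible. The expected step is an at least 1.6-fold lower number from compound 3 to compound 4 (0.22 log units; that floor lies within the scatter). Compound 4 is estimated at 90000 nM, with an expected range from 30000 nM to 150000 nM.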

Compound 4, half-maximal cytotoxic concentration: 120000 nM
Estimate against measurement, compound 4: 1.3-fold (0.12 log units) below; low and high end bracket the measured number.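

In this assay compound 4 gives 120000 nM, which shows that a far larger group at this place, (4-chlorophenoxy)methyl with its six-membered aromatic ring of carbon only, can still leave a number inside the range of the assay. The comparisons with the two smaller groups, an at least 1.2-fold lower number from compound 3 to compound 4 (0.09 log units; that floor lies within the scatter) and an at least 1.2-fold lower number from compound 2 to compound 4 (0.09 log units; that floor lies within the scatter), show no change beyond the scatter, and they remain floors rather than sizes because each one ends at a limit: the limit of > 150000 nM in this assay, at which 2 of the 4 values shown sit. Within the data shown here, the only comparison between two actual numbers at this place is a 1.5-fold higher number from compound 1 to compound 4 (0.18 log units; within the scatter), so dimethylamino and (4-chlorophenoxy)methyl cannot be told apart here, despite the difference in size between the two groups.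

The compounds shown leave open how much of the result for compound 4 belongs to its chlorine, its oxygen or its added ring, and what a plain phenoxymethyl group would give at this place. They also leave open whether a carboxylic acid or a primary amine at this place would lower the tolerated concentration clearly beyond the scatter, which no group shown so far has been seen to do.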